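Amide aryl swap on a catechol-ether amide series

The source may hold more compounds than are shown below. What is called first, only, known or untested is meant among the compounds shown, and "the series" means these compounds.

Compound 1 `COc1ccc(C(=O)Nc2c(F)cccc2F)cc1OC1CCCC1` gives 70 nM in an assay on isolated protein for inhibition of phosphodiesterase 4A (Sus scrofa) (a lower number here means a stronger inhibitor, a higher number a weaker inhibitor), the lowest of the three numbers. Compound 2 `COc1ccc(C(=O)Nc2c(F)cccc2F)cc1OC` gives 900 nM, and compound 3 `O=C(Nc1c(F)cccc1F)c1cccc(OC2CCCC2)c1` gives 15000 nM. Both measured steps concern the ether side of the shared core: a 13-fold higher number from compound 1 to compound 2 (1.11 log units; beyond the scatter) and a 210-fold higher number from compound 1 to compound 3 (2.33 log units; beyond the scatter). Compound 4 `COc1ccc(C(=O)Nc2ncccc2C)cc1OC1CCCC1` instead alters the amide side: 3-methylpyridin-2-yl in place of 2,6-difluorophenyl on an amide-type nitrogen. Going by the values given here, neither measured step touches the amide-type nitrogen, so no step bears directly on this change; the only guide is that compound 1 sits at the strong end with 70 nM and the ether side of the core is kept intact. A modest weakening is expected, as a step of a 1.7-fold higher number from compound 1 to compound 4 (0.23 log units; within the scatter). Compound 4 is estimated at 120 nM, within 25 nM to 600 nM.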

Compound 4, half-maximal inhibitory concentration: 3100 nM
For compound 4 the middle estimate is 26-fold (1.41 log units) below the measured one, outside the stated range (above it).
By their numbers in this assay, from the lowest: compound 1; then compound 2; then compound 4; then compound 3.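

In this assay, 3-methylpyridin-2-yl in place of 2,6-difluorophenyl on the amide-type nitrogen gives a 44-fold higher number from compound 1 to compound 4 (1.65 log units; beyond the scatter), with the ether side of the core left intact. The group on this nitrogen is therefore a second place where the series responds strongly, alongside the ether side. No available data explain this loss.

From the compounds shown here alone, the swap changes the ring atoms and the ring substituents together, so the share of each in the step remains open. Also open, going by these compounds, is how a plain phenyl on the same nitrogen would compare with compound 1 and compound 4.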